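The source may report more compounds than this note shows. Statements on the series, on what has been measured and on what is new or still open speak of the compounds shown alone.

Working notes on the series. Compound 1 `O=C(Nc1ccc(Oc2ccnc3[nH]ccc23)cc1)c1cc2cccnc2n(-c2ccccc2)c1=O` carries an unsubstituted phenyl on the shared core; in a functional assay on HT-29 cells (Homo sapiens) for antiproliferative activity, read by MTT assay, with a stated time of 72 h (a higher number here means a weaker inhibitor, a lower number a stronger inhibitor), compound 1 gives 290 nM. Compound 2 `O=C(Nc1ccc(Oc2ccnc3[nH]ccc23)cc1)c1cc2cccnc2n(-c2ccc(F)cc2)c1=O` differs by one fluorine, and in this assay compound 2 gives 160 nM. Going by the values given here, the only step so far, a 1.8-fold lower number from compound 1 to compound 2 (0.26 log units; within the scatter), stays within the scatter, so compound 2 holds the lower of the two numbers without standing apart from compound 1.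

Compound 3 `O=C(Nc1ccc(Oc2ccnc3[nH]ccc23)cc1)c1cc2cccnc2n(-c2ccc(Cl)cc2)c1=O` is the next member: chloro in place of fluoro on an aromatic carbon. Among the compounds with values here, the one measured step that bears on this position, a 1.8-fold lower number from compound 1 to compound 2 (0.26 log units; within the scatter), suggests the group sitting at this carbon has so far moved the number little. A halogen exchange at the same place is therefore expected to give no step beyond the scatter, a 1.1-fold lower number from compound 2 to compound 3 (0.06 log units; within the scatter), and for compound 3 in this assay the estimate is 140 nM, with a range from 60 nM to 350 nM.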

Compound 3, half-maximal inhibitory concentration: 280 nM
Compound 3: middle estimate off by 2.0-fold (0.30 log units), on the low side; low and high end bracket the measured number.
By their numbers in this assay, from the lowest: compounds 2, 3 and 1 (each within the scatter of the next).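

In this assay chloro in place of fluoro gives a 1.8-fold higher number from compound 2 to compound 3 (0.24 log units; within the scatter) and chloro in place of hydrogen gives a 1.0-fold lower number from compound 1 to compound 3 (0.02 log units; within the scatter) on the same aromatic carbon. With hydrogen, fluoro and chloro now compared at this carbon, every step among compounds 1, 2 and 3 lies within the scatter, so the second halogen adds a further case in which the group at this place does not separate the compounds in this assay. No evidence is available that would explain these numbers. From the compounds shown here alone, whether this position stays as flat with groups of another kind remains open, since an amine, a methoxy group or a carboxylic acid on this carbon would be a different test from a halogen exchange. The compounds shown also leave open how changes elsewhere on the shared core would read in this assay.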